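Iodo on the shared core: still inactive against colon cancer cells?

The source may report more compounds than this note shows. Statements on the series, on what has been measured and on what is new or still open speak of the compounds shown alone.

Compound 1 `O=c1nc(NO)cc[nH]1` gives > 100000 nM in a functional assay on SW-620 cells (Homo sapiens) for inhibition, read by MTT assay, with a stated time of 72 h; a higher number here means a weaker inhibitor, a lower number a stronger inhibitor.
Compound 2 `Cc1cc(=O)[nH]c(=O)n1COC(CO)CO` gives > 100000 nM in this assay.
Compound 3 `O=c1ccn(COC(CO)CO)c(=O)[nH]1` gives > 100000 nM in this assay.

Each of these three values is a limit of the assay, not a number: none of the compounds inhibited the cells strongly enough for a concentration to be read. Compound 2 therefore stands only at this limit, and nothing separates it from the others (the limit of > 100000 nM in this assay, at which 3 of the 3 values shown sit).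

Compound 4 `Cc1c(I)c(=O)[nH]c(=O)n1COC(CO)CO` is compound 2 with one change (iodo in place of hydrogen on an aromatic carbon).

Within the data shown here, the only measured step that touches the same core is the one from compound 2 to compound 3, but it reads a step that the two limits leave unreadable from compound 2 to compound 3; both ends sit at the limit, so its size cannot be read, and it says nothing about an iodo entering at this position. With every shown value at the limit, there is no measured step that points to a gain or a loss, so no movement beyond the scatter in this assay can be expected from the data. The step from compound 2 to compound 4 is thus estimated as a number no higher from compound 2 to compound 4 (the limit leaves the size open).

Compound 4 is expected to give about 100000 nM, in a range from 30000 nM to 300000 nM, most likely reported again only as a limit.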

Compound 4, half-maximal inhibitory concentration: > 100000 nM
Compound 4: only a limit was reported (the forecaster's own chance of this, stated with the estimate: 80%); the middle value sits exactly at the limit.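

Compound 4, like compound 2, gives only a limit and not a number, so the step between these two compounds cannot be read, and the iodo shows neither a gain nor a loss: the limit of > 100000 nM in this assay, at which 4 of the 4 values shown sit.

The compounds shown leave open whether any change on the shared core can give a readable value in this assay.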